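Trading an Isobutyl Group for Chloro on the Shared Core

This account rests on a few compounds, and the source may have more. Where it says the series, first, only, none or still open, it means among the compounds named here.

Measured so far:
Compound 1, `C[C@@H](Oc1cc2onc(CCC(=O)O)c2cc1Cl)c1ccc(F)cn1`, gives 3.16 nM.
Compound 2, `CC(C)Cc1cc2oc(=O)n(CCC(=O)O)c2cc1Cl`, gives 12.6 nM.
Compound 3, `Cc1ccnc([C@@H](C)Oc2cc3oc(=O)n(CCC(=O)O)c3cc2Cl)c1`, gives 3.98 nM.

All three were tested in an assay for inhibition of kynurenine 3-monooxygenase (Homo sapiens), read by mass spectrometry, with a stated time of 1 h; a higher number here means a weaker inhibitor, a lower number a stronger inhibitor. Among them compound 2 stands at the highest number, so it is the weakest inhibitor of the three: its steps to compound 3 and to compound 1 both lie beyond the scatter, with compound 3 nearest and compound 1 furthest away. The other two compounds carry a larger ether-linked group at the position where compound 2 carries an isobutyl group.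

The next compound, compound 4, `O=C(O)CCn1c(=O)oc2cc(Cl)c(Cl)cc21`, keeps the core of compound 2 and changes a single spot: chloro in place of isobutyl on an aromatic carbon. The isobutyl group leaves and a chloro group enters, so the larger group at that position is replaced by a single atom.

Within the data shown here, no measured pair shows this particular exchange. Since the compounds with larger groups at this position gave the lower numbers, the step from compound 2 to compound 4 is expected to raise the number in this assay, beyond the scatter, as a 4.0-fold higher number from compound 2 to compound 4 (0.60 log units; beyond the scatter). Compound 4 is therefore estimated at 50 nM, within a range from 15 nM to 200 nM.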

Compound 4, half-maximal inhibitory concentration: 6.31 nM
The estimate for compound 4 lay 7.9-fold (0.90 log units) above the measured number, and the stated range ends above it.
By their numbers in this assay, from the lowest: compounds 1, 3, 4 and 2 (each within the scatter of the next, the first and the last beyond it).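

In this assay, replacing the isobutyl group with chloro gives a 2.0-fold lower number from compound 2 to compound 4 (0.30 log units; within the scatter), so at this position a single chlorine atom does as well as the four-carbon chain, within the usual variation between repeats. The earlier compounds shown here hinted that larger groups here go with lower numbers, but compound 4 does not fit that picture: with only one heavy atom at this spot, it gives 6.31 nM, while compound 3, with its larger ether-linked group, gives 3.98 nM. Nothing available explains why isobutyl and chloro read so alike here.

From the compounds shown here alone, it remains open how the number would respond to a bare hydrogen, a methoxy group or an amine at this position. Going by these compounds, it is also open whether chloro in place of isobutyl would read the same way on the core of compound 1.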